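The compounds below may be only part of what the source reports. "The series", "measured", "known", "first", "only" and "open" are said of these compounds alone.

Measured so far:
- compound 3, `Nc1nc(Nc2ccc(N3CCN(C4CC5CCC4C5)CC3)cc2)nn1-c1nccc2ccccc12`: 8.8 L/kg
- compound 1, `Cc1nc(-n2nc(Nc3ccc(N4CCN(C5CC6CCC5C6)CC4)cc3)nc2N)c2ccccc2n1`: "not determined" (no result reported)
- compound 2, `Nc1nc(Nc2ccc(N3CCN(C4CC5CCC4C5)CC3)cc2)nn1-c1ncnc2ccc(Cl)cc12`: "not determined" (no result reported)

Among the measured compounds shown here, compound 3 is the only member of the series with a number in an ADME assay on the whole organism (strain Sprague-Dawley) for pharmacokinetics, with Rattus norvegicus as the target; on this read-out lower numbers stand for narrower distribution and higher numbers for wider distribution into tissues; compound 1 gives "not determined" (no result reported) and compound 2 gives "not determined" (no result reported) in this assay, so no step between measured compounds can be drawn and compound 3 stands alone as the sole reference point. In this assay compound 3 gives 8.8 L/kg, a wide distribution into tissues.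

Compound 4, `Nc1nc(Nc2ccc(N3CCN(C4CC5CCC4C5)CC3)cc2)nn1-c1ncnc2ccc(F)cc12`, is the next entry to be measured. It differs from compound 3 in one place: 6-fluoroquinazolin-4-yl in place of isoquinolin-1-yl on an aromatic nitrogen. The shared core, the anilino linker and the bicyclic piperazine substituent are unchanged.

For the measured compounds named here, with no step between measured compounds to lean on, the expectation rests on compound 3 alone. The exchange on the aromatic nitrogen is not expected to move this read-out beyond the scatter; a modest step of a 1.4-fold lower number from compound 3 to compound 4 (0.13 log units; within the scatter) is expected, leaning toward a somewhat narrower distribution. Compound 4 is therefore estimated at 6.5 L/kg in this assay, within 3 L/kg to 13 L/kg.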

Compound 4, volume of distribution at steady state: 7.9 L/kg
Estimate against measurement, compound 4: 1.2-fold (0.08 log units) below; measured number inside the range.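

In this assay, 6-fluoroquinazolin-4-yl in place of isoquinolin-1-yl on the aromatic nitrogen gives a 1.1-fold lower number from compound 3 to compound 4 (0.05 log units; within the scatter) and so gives this position its first readable step. Wide distribution into tissues therefore holds across this exchange, with compound 4 at 7.9 L/kg as a second reference point. The extra ring nitrogen and the fluorine enter together, so this single step cannot separate them, and nothing measured here bears on why the read-out holds.

Steps to compound 1 and compound 2 cannot be read, so the methyl and chloro variants add nothing at this position. Still open, from the compounds shown here alone, is whether a more different group on the aromatic nitrogen, such as a phenyl ring bearing a carboxylic acid or an aliphatic amine, would move the read-out beyond the scatter.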